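Swapping 3-bromophenyl for 4-aminophenyl at the assay limit

The compounds below may be only part of what the source reports. "The series", "measured", "known", "first", "only" and "open" are said of these compounds alone.

- Compound 1 `Fc1cccc(-c2nc(Nc3ccccc3)c3cc(F)ccc3n2)c1`: 49700 nM
- Compound 2 `Fc1ccc(Nc2nc(-c3cccc(F)c3)nc3ccc(F)cc23)cc1`: > 50000 nM
- Compound 3 `Fc1cccc(-c2nc(Nc3cccc(Br)c3)c3cc(F)ccc3n2)c1`: > 50000 nM

These results come from a functional assay on MCF7 cells (Homo sapiens) for cytotoxicity, read by MTT assay, with a stated time of 48 h; on this read-out higher numbers stand for weaker inhibition and lower numbers for stronger inhibition. Compound 2 gives only a limit, not a number. Compound 3 also gives only a limit, standing at the limit of > 50000 nM in this assay, at which 2 of the 3 values shown sit.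

Compound 4 `Nc1ccc(Nc2nc(-c3cccc(F)c3)nc3ccc(F)cc23)cc1` differs from compound 3 by 4-aminophenyl in place of 3-bromophenyl on a nitrogen on an aromatic ring. Two measured steps change the same group on that nitrogen: a number no lower from compound 1 to compound 2 (the limit leaves the size open) and a number no lower from compound 1 to compound 3 (the limit leaves the size open). A third is a step that the two limits leave unreadable from compound 2 to compound 3. None has a readable size, and none introduces an amino group. Among the measured compounds shown here, the only exact number is from compound 1 at 49700 nM, so a small move toward stronger inhibition is expected, possibly none. The expected change is an at least 1.2-fold lower number from compound 3 to compound 4 (0.09 log units; that floor lies within the scatter). For compound 4 the estimated value is 40000 nM, with an expected range of 12000 nM to 60000 nM.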

Compound 4, half-maximal inhibitory concentration: > 50000 nM
Compound 4: only a limit was reported; the forecaster's own chance of this, stated with the estimate: 50%; at least 1.2-fold (0.09 log units) between middle value and limit.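

In this assay, compound 4 gives only a limit, so 4-aminophenyl on this nitrogen joins 4-fluorophenyl and 3-bromophenyl in giving no exact number, and of the new steps only a number no lower from compound 1 to compound 4 (the limit leaves the size open) shows a direction. Among the compounds shown here, none of the new steps can be read for size, so an amino group, the one change here that adds a hydrogen-bond donor, brings no measurable shift. The limit now covers most of the series: the limit of > 50000 nM in this assay, at which 3 of the 4 values shown sit.

From the compounds shown here alone, how far compounds 2, 3 and 4 differ from one another stays open. Going by these compounds, whether a carboxylic acid or a methoxy group at this place would give a readable number also stays open.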